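A Propyl Chain Added to Compound 2: What to Expect

The source may hold more compounds than are shown below. What is called first, only, known or untested is meant among the compounds shown, and "the series" means these compounds.

Three measured compounds share a core in which a phenol-bearing methylene amine is joined to a ring that carries a varied group. Compound 2 `Oc1ccccc1CNc1ccc(-c2ccccc2)cc1` carries a phenyl group, and in a functional assay on Jurkat cells (Homo sapiens) for activation, with a stated time of 24 h (a lower number here means that less compound is needed, a higher number that more compound is needed for the effect), compound 2 gives 1820 nM, the lowest of the two numbers recorded. Compound 3 `Oc1ccccc1CNc1ccc(C2CCCCC2)cc1` carries cyclohexyl in place of phenyl on an aromatic carbon; in this assay compound 3 gives 8800 nM, which amounts to a 4.8-fold higher number from compound 2 to compound 3 (0.68 log units; beyond the scatter). Compound 1 `Oc1ccccc1CNc1ccc(N2CCNCC2)cc1` carries a different ring, and in this assay compound 1 is reported as "not active" (no number reported), with no number given.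

Compound 4 `CCCc1ccc(-c2ccc(NCc3ccccc3O)cc2)cc1` differs from compound 2 by propyl in place of hydrogen on an aromatic carbon. For the measured compounds named here, no measured step adds a chain to an existing ring; the only step, a 4.8-fold higher number from compound 2 to compound 3 (0.68 log units; beyond the scatter), swaps one ring for another and so does not bear directly on this change. With nothing to point either way, the step from compound 2 to compound 4 is expected to be a 1.1-fold lower number from compound 2 to compound 4 (0.06 log units; within the scatter), within the scatter. Compound 4 is therefore estimated to give 1600 nM, with a range from 500 nM to 5000 nM.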

Compound 4, half-maximal effective concentration: 2390 nM
Estimate against measurement, compound 4: 1.5-fold (0.17 log units) below; measured number inside the range.
By their numbers in this assay, from the lowest: compounds 2 and 4 (each within the scatter of the next); then compound 3.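

In this assay, for the compounds shown here, propyl in place of hydrogen on an aromatic carbon, para to a large group, gives a 1.3-fold higher number from compound 2 to compound 4 (0.12 log units; within the scatter) and so adds a chain to an existing ring for the first time. Unlike the ring swap, which gave a 4.8-fold higher number from compound 2 to compound 3 (0.68 log units; beyond the scatter) and moved the number beyond the scatter, this added chain leaves a change that cannot be told from the scatter. So this position can carry a propyl chain with the number staying in the same range as before. Nothing measured here explains this result.

On these data alone, whether a longer chain such as hexyl, or an amine or a carboxylic acid, at this same position would give a similar number remains open. As far as these compounds go, compound 2 gives 1820 nM, and also open is whether any group there could bring the number clearly lower.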